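This account rests on a few compounds, and the source may have more. Where it says the series, first, only, none or still open, it means among the compounds named here.

Of the compounds shown here, two built on one shared core have so far been measured in a functional assay on 3T3-L1 cells (Mus musculus) for inhibition, with a stated time of 20 min, tested at 20 uM; on this read-out lower numbers stand for less inhibition and higher numbers for more inhibition at the one concentration tested (going by the name of the read-out). Compound 1 `Cc1ccc(S(=O)(=O)n2cc(CN(Cc3cccc(F)c3F)C(=O)C(F)(F)F)c3ccccc32)cc1` gives -5.5% in this assay, and compound 2 `O=S(=O)(c1ccc(F)cc1)N(Cc1cccc(F)c1F)Cc1cn(S(=O)(=O)c2ccc(F)cc2)c2ccccc12` gives -20% in this assay. Compound 2 stands lowest of the two numbers; its nearest neighbour, compound 1, lies higher by an amount beyond the usual scatter, yet neither number points to appreciable inhibition at the single concentration tested. Compound 3 `O=S(=O)(c1ccc(F)cc1)n1cc(CNCc2cccc(F)c2F)c2ccccc21` has not yet been measured. It differs from compound 2 in one place: hydrogen in place of (4-fluorophenyl)sulfonyl on an amine nitrogen. For the measured compounds named here, no step between two measured compounds is available to calibrate a change of this kind, so the expectation rests on the two numbers alone, both sitting at or beneath zero. For compound 3 the expected change is small, a number 15 percentage points higher from compound 2 to compound 3 (beyond the scatter), pointing toward a less negative number if anything. Compound 3 is estimated at -5%, within a range from -25% to 15%.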

Compound 3, a percentage reported as inhibition, at one concentration (the size of the read-out at that concentration, not a potency): 21%
Compound 3: middle estimate off by 26 percentage points, on the low side, and the stated range ends below it.
By their numbers in this assay, from the lowest: compound 2; then compound 1; then compound 3.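

Taking the (4-fluorophenyl)sulfonyl group off the amine nitrogen and leaving a hydrogen there produces a large change in this assay: a number 41 percentage points higher from compound 2 to compound 3 (beyond the scatter). This nitrogen is therefore a place where the choice of group strongly affects the read-out, and the change carries the number from below zero to above it, with compound 3 at 21% showing measurable inhibition at the one concentration tested. No available measurement explains why this swap has such an effect.

One step cannot show whether the hydrogen itself is needed, or whether a methyl or an acetyl group on the same nitrogen would keep the number of compound 3. On these data alone, how compound 3 behaves at other concentrations also remains open, so its potency is unknown.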